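Aspartamide analogue in the purine glycinamide ester series

This account rests on a few compounds, and the source may have more. Where it says the series, first, only, none or still open, it means among the compounds named here.

Three benzyl esters on the shared core have been run in a functional assay on the whole organism (Tail, strain ICR) with Mus musculus as the target, in the tail flick test, with a stated time of 120 min, at a dose of 25 umol/kg by the oral route; a lower number here means a weaker effect, a higher number a stronger effect of the compound at the dose given. Compound 3 `C[C@H](NC(=O)CN(c1nc(Cl)nc2[nH]cnc12)C1CC1)C(=O)OCc1ccccc1` gives 36.1%, the highest of the three numbers. Compound 2 `O=C(CN(c1nc(Cl)nc2[nH]cnc12)C1CC1)NCC(=O)OCc1ccccc1` gives 21.7%, and compound 1 `N=C(N)NCCC[C@H](NC(=O)CN(c1nc(Cl)nc2[nH]cnc12)C1CC1)C(=O)OCc1ccccc1` gives 10.2%. Both steps to compound 3 go upward: a number 14.4 percentage points higher from compound 2 to compound 3 (beyond the scatter) and a number 25.9 percentage points higher from compound 1 to compound 3 (beyond the scatter); the step of a number 11.5 percentage points higher from compound 1 to compound 2 (beyond the scatter) points the same way.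

Compound 4 `NC(=O)C[C@H](NC(=O)CN(c1nc(Cl)nc2[nH]cnc12)C1CC1)C(=O)OCc1ccccc1` is the next member to be run. It differs from compound 3 by carbamoyl in place of hydrogen on a saturated chain carbon, two bonds along the chain from an amide-type nitrogen and a carbonyl carbon. For the measured compounds named here, the step that bears most directly on this is the one from compound 1 to compound 3, in which a group of six heavy atoms at the same place was replaced by hydrogen and the number rose by a number 25.9 percentage points higher from compound 1 to compound 3 (beyond the scatter). Carbamoyl is a smaller group than the one lost there, so the reverse step is expected to cost less than the whole of that gain, but a decrease is expected because of a number 25.9 percentage points higher from compound 1 to compound 3 (beyond the scatter). The step from compound 3 to compound 4 is therefore estimated as a number 16.1 percentage points lower from compound 3 to compound 4 (beyond the scatter). On that basis compound 4 is expected to give 20%, with a range from 6% to 36%.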

Compound 4, a percentage reported as activity, at one dose (the size of the read-out at that dose, not a potency): 15.1%
For compound 4 the middle estimate is 4.9 percentage points above the measured one, within the range that was stated.
By their numbers in this assay, from the lowest: compounds 1, 4 and 2 (each within the scatter of the next, the first and the last beyond it); then compound 3.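

Notes on the side chain: in this assay, a number 21 percentage points lower from compound 3 to compound 4 (beyond the scatter), so carbamoylmethyl at this saturated chain carbon does not keep the level reached with methyl. Carbamoylmethyl and hydrogen at this carbon cannot be told apart (a number 6.6 percentage points lower from compound 2 to compound 4 (within the scatter)), nor can the carbamoylmethyl chain and the larger six-heavy-atom chain of compound 1 (a number 4.9 percentage points higher from compound 1 to compound 4 (within the scatter)), so among these four compounds only methyl stands clear of the rest. No measurement on these compounds accounts for this.

Open, on these data alone, is whether ethyl, a primary amine or a carboxylic acid on this carbon would read with compound 3 or with compound 4. Also open, as far as these compounds go, is whether a longer chain ending in carbamoyl would read with compound 4.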